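The compounds below may be only part of what the source reports. "The series", "measured", "known", "first", "only" and "open" are said of these compounds alone.

Working notes on the series. Among the measured compounds shown here, in a functional assay on TM4 cells (Mus musculus) for cytotoxicity, read by MTT assay, with a stated time of 72 h (a lower number here means a stronger inhibitor, a higher number a weaker inhibitor), compound 1 (`Nc1nc(Nc2ccccc2)sc1C(=O)c1ccc(F)cc1`) gives 14000 nM and compound 2 (`Nc1nc(Nc2ccccc2)sc1C(=O)c1cccc(F)c1`) gives 5100 nM as the lower of the two numbers so far. Compound 3 (`NC(=O)c1sc(Nc2ccccc2)nc1N`) differs from compound 2 at one place: amino in place of 3-fluorophenyl on a carbonyl carbon and so amino in place of 3-fluorophenyl on a carbonyl carbon. For the measured compounds named here, only one measured step bears on this, a 2.7-fold lower number from compound 1 to compound 2 (0.44 log units; beyond the scatter) and it is modest, though beyond the scatter. That step swaps one fluorophenyl group for another, whereas here the whole ring leaves, so it sets only a rough floor on the size. Going by the values given here, no measured compound lacks this ring. A larger step towards a higher number in this assay is expected, with wide uncertainty. The estimated change is a 4.9-fold higher number from compound 2 to compound 3 (0.69 log units; beyond the scatter) in this expectation. For compound 3 the expected value is 25000 nM with an estimated range from 7000 nM to 90000 nM at its ends.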

Compound 3, half-maximal inhibitory concentration: > 60000 nM
Compound 3: a limit, no number; the forecaster's own chance of this, stated with the estimate: 25%; middle value at least 2.4-fold (0.38 log units) away from the limit.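

In this assay compound 3 gives a limit and not a number: the limit of > 60000 nM in this assay, at which 1 of the 3 values shown sits. Amino in place of 3-fluorophenyl on the carbonyl carbon gives an at least 11-fold higher number from compound 2 to compound 3 (1.07 log units; beyond the scatter), and amino in place of 4-fluorophenyl gives an at least 4.2-fold higher number from compound 1 to compound 3 (0.63 log units; beyond the scatter). The earlier compounds shown here showed only that moving the fluorine on a retained ring shifts the number, whereas this change shows that removing the ring altogether takes the series to a higher number than either fluorophenyl compound gives.

On these data alone, compound 3 carries only a limit, so the full size of both steps stays open. As far as these compounds go, it also remains open whether any carbon group on the carbonyl carbon holds the lower numbers or only a fluorophenyl does; an unsubstituted phenyl, a methyl or a longer alkyl chain there would tell these apart.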